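Replacing the 4-chlorophenyl group of compound 2

The source may report more compounds than this note shows. Statements on the series, on what has been measured and on what is new or still open speak of the compounds shown alone.

Of the compounds shown here, two with a shared core have so far been tested in an ADME assay on HCT-116 cells (Homo sapiens) for cytotoxicity; a higher number here means that more compound is tolerated, a lower number that less compound is tolerated. Compound 1 `Cc1ccc(-n2c(SCC(=O)NNC(=O)c3ccccc3O)nnc2-c2ccccc2O)cc1` gives > 20000 nM, which is a limit of the assay and not a number. Compound 2 `O=C(CSc1nnc(-c2ccc(Cl)cc2)n1-c1ccccc1)NNC(=O)c1ccccc1O` gives > 20000 nM, which is likewise a limit and not a number. Compound 2 therefore has no exact value of its own and stands with compound 1 at the same mark: the limit of > 20000 nM in this assay, at which 2 of the 2 values shown sit.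

Compound 3 `Cc1cc(C)nc(SCc2nnc(SCC(=O)NNC(=O)c3ccccc3O)n2-c2ccccc2)n1` has ((4,6-dimethylpyrimidin-2-yl)sulfanyl)methyl in place of 4-chlorophenyl on an aromatic carbon of a five-membered aromatic ring with 3 nitrogen. The change from compound 2 counts as follows: ((4,6-dimethylpyrimidin-2-yl)sulfanyl)methyl in place of 4-chlorophenyl on an aromatic carbon.

For the measured compounds named here, no measured pair of compounds differs in one place only, so the expectation rests on the shared limit alone. No step beyond the scatter, in either direction, is expected in this assay. The estimated step is a number no higher from compound 2 to compound 3 (the limit leaves the size open). Compound 3 is expected at about 20000 nM, with an estimated range of 8000 nM to 40000 nM.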

Compound 3, half-maximal cytotoxic concentration: > 20000 nM
Compound 3 ended at the assay's limit; the forecaster's own chance of this, stated with the estimate: 80%; the middle value sits exactly at the limit.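

In this assay compound 3 gives > 20000 nM, which is a limit of the assay and not a number. For the compounds shown here, compound 2 also stands at a limit, so no step between compound 2 and compound 3 can be read. The compounds shown leave open what concentration of any of them is actually cytotoxic, and whether any group at this place would give an exact value.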